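Acetamido to Cyano: What Compound 3 Might Tolerate

The source may report more compounds than this note shows. Statements on the series, on what has been measured and on what is new or still open speak of the compounds shown alone.

Measured so far:
compound 1, `CNS(=O)(=O)c1cc(O)c(O)c(C(=O)NCc2ccc(F)cc2)c1`, > 40000 nM
compound 2, `CC(=O)Nc1cc(O)c(O)c(C(=O)NCc2ccc(F)cc2)c1`, < 10000 nM

In an ADME assay on NCI-H630 cells (Homo sapiens) for cytotoxicity, read by MTT assay, with a stated time of 72 h (a lower number here means that less compound is tolerated, a higher number that more compound is tolerated), compound 1 gives > 40000 nM, which is a limit of the assay rather than a number (the limit of > 40000 nM in this assay, at which 1 of the 2 values shown sits). In this assay compound 2 gives < 10000 nM, again only a limit and not a number (the limit of < 10000 nM in this assay, at which 1 of the 2 values shown sits). Among the measured compounds shown here, the single measured step is an at least 4.0-fold lower number from compound 1 to compound 2 (0.60 log units; beyond the scatter). Both ends of this step sit at limits, so its true size is not known beyond being at least that large. For the measured compounds named here, compound 2 therefore stands only at a limit, and the one other value shown is a limit as well.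

Compound 3 `N#Cc1cc(O)c(O)c(C(=O)NCc2ccc(F)cc2)c1` differs from compound 2 in one place: cyano in place of acetamido on an aromatic carbon. Going by the values given here, the measured step bears on it only in that it changes the same position; no measured step involves a cyano group, so its direction for this assay is not fixed by the data. With so little to go on, compound 3 is expected to show a step that the limit leaves unreadable from compound 2 to compound 3, that is no change beyond the scatter, and its value in this assay is estimated at 7000 nM, between 2000 nM and 30000 nM.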

Compound 3, half-maximal cytotoxic concentration: > 10000 nM
Compound 3: only a limit was reported; the forecaster's own chance of this, stated with the estimate: 40%; at least 1.4-fold (0.15 log units) between middle value and limit.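

At this position, para to a hydroxy group, cyano in place of acetamido gives a number no lower from compound 2 to compound 3 (the limit leaves the size open) in this assay. The low reading seen with acetamido therefore does not carry over to cyano on this aromatic carbon, which shows that the result here depends on the group and does not follow from any change away from methylsulfamoyl, while the step from compound 1 to compound 3 cannot be read. Compound 3 gives > 10000 nM, which is a limit and not a number: the limit of > 10000 nM in this assay, at which 1 of the 3 values shown sits.

Going by these compounds, how far compound 3 lies from compound 2 remains open, and so does whether cyano and methylsulfamoyl differ at all in this assay. On these data alone, it is also open whether an amine or a carboxylic acid on this aromatic carbon would go with acetamido or with the other two groups.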